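A few compounds are considered here, and "the series" means these few. Any claim that something is new, unique, unknown or untested is made for them only; others in the source may bear on it.

Measured so far:
Compound 1, `CNC(=O)c1cc(Oc2ccc(Nc3nccc(N4CCCC4)n3)cc2)ccn1`: 66.4%
Compound 2, `c1ccc2c(c1)CCN(c1ccnc(Nc3ccc(Oc4ncnc5ccsc45)cc3)n1)C2`: 40.9%

In a functional assay on HCT-116 cells (Homo sapiens) for inhibition, read by MTT assay, with a stated time of 72 h, tested at 20 uM (a lower number here means less inhibition, a higher number more inhibition at the concentration tested (going by the name of the read-out)), compound 2 stands lowest of the two numbers shown; compound 1 gives 66.4% and compound 2 gives 40.9%, a gap beyond the usual scatter. Compound 3, `CNC(=O)c1cc(Oc2ccc(Nc3nccc(N4CCc5ccccc5C4)n3)cc2)ccn1`, has not been measured. Relative to compound 2 the change is a group of 10 heavy atoms (7 carbon, 2 nitrogen, 1 oxygen; one six-membered aromatic ring with 1 hetero atom) in place of a group of 9 heavy atoms (6 carbon, 2 nitrogen, 1 sulfur; one five-membered aromatic ring with 1 hetero atom, one six-membered aromatic ring with 2 hetero atoms), on an oxygen on an aromatic ring. Going by the values given here, no step between measured compounds is recorded. Among the compounds with values here, the group that enters in compound 3 is the one carried by compound 1, which gave 66.4%, so a rise beyond the scatter is expected, about a number 19.1 percentage points higher from compound 2 to compound 3 (beyond the scatter). Compound 3 is estimated at 60%, within 38% to 80%.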

Compound 3, a percentage reported as inhibition, at one concentration (the size of the read-out at that concentration, not a potency): 31.2%
Estimate against measurement, compound 3: 28.8 percentage points above, and the stated range ends above it.
By their numbers in this assay, from the lowest: compounds 3 and 2 (each within the scatter of the next); then compound 1.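

In this assay, exchanging the group on the oxygen on an aromatic ring for 2-(methylcarbamoyl)pyridin-4-yl, with 1,2,3,4-tetrahydroisoquinolin-2-yl present, gives a number 9.7 percentage points lower from compound 2 to compound 3 (within the scatter), so this change leaves the read-out within the scatter. With 2-(methylcarbamoyl)pyridin-4-yl held fixed, 1,2,3,4-tetrahydroisoquinolin-2-yl in place of pyrrolidin-1-yl on the aromatic carbon gives a number 35.2 percentage points lower from compound 1 to compound 3 (beyond the scatter), a large step. Nothing available explains either step. Open, from the compounds shown here alone, is whether pyrrolidin-1-yl keeps its higher number with the other group on the oxygen. Also open, going by these compounds, is how a morpholin-4-yl or a piperidin-1-yl group on that aromatic carbon would read.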